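The source may report more compounds than this note shows. Statements on the series, on what has been measured and on what is new or still open speak of the compounds shown alone.

Measured so far in a functional assay on Hs-578T cells (Homo sapiens) for inhibition, read by sulforhodamine B assay, with a stated time of 48 h, tested at 10 uM; on this read-out higher numbers stand for a weaker effect at the one concentration tested and lower numbers for a stronger effect:

compound 1, `COc1cc(Cl)cc(-c2nn(-c3cccc(NC(=O)c4cccc(C(F)(F)F)c4)c3)cc2-c2ccncc2)c1` — compound 1 gives 62.2%
compound 2, `O=C(Nc1cccc(-n2cc(-c3ccncc3)c(-c3cc(O)cc(Cl)c3)n2)c1)c1cc(C(F)(F)F)cc(C(F)(F)F)c1` — compound 2 gives 65.9%

Among the measured compounds shown here, the two numbers lie within the usual scatter of each other, so compound 2 does not stand apart from compound 1 in this assay, and the pair yields no separable step. The two compounds also differ in more than one place, so no single change can be read from them.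

Compound 3, `COc1cc(Cl)cc(-c2nn(-c3cccc(NC(=O)c4cc(C(F)(F)F)cc(C(F)(F)F)c4)c3)cc2-c2ccncc2)c1`, is still to be measured. It differs from compound 2 in one place: methyl in place of hydrogen on an oxygen on an aromatic ring. Compound 1 already carries the methoxy group, together with a single trifluoromethyl group, and its number in this assay sits close to that of compound 2. On that basis the step of a number 1.9 percentage points lower from compound 2 to compound 3 (within the scatter) is expected to stay within the scatter, with no direction claimed. Compound 3 is estimated at 64% in this assay, with a range from 50% to 78%.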

Compound 3, a percentage reported as activity, at one concentration (the size of the read-out at that concentration, not a potency): 81.1%
For compound 3 the middle estimate is 17.1 percentage points below the measured one, and the stated range ends below it.
By their numbers in this assay, from the lowest: compounds 1 and 2 (each within the scatter of the next); then compound 3.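

With both trifluoromethyl groups kept, the change from hydroxy to methoxy on the aromatic ring gives a number 15.2 percentage points higher from compound 2 to compound 3 (beyond the scatter) in this assay, so at this oxygen methyl does not read as equivalent to hydrogen, and the methoxy compound shows the weaker effect at the one concentration tested. With methoxy kept, trifluoromethyl in place of hydrogen on an aromatic carbon gives a number 18.9 percentage points higher from compound 1 to compound 3 (beyond the scatter), a step towards a weaker effect as well, so each of the two changes can now be read on its own. Nothing available explains either step.

From the compounds shown here alone, whether the step from hydroxy to methoxy keeps its size with a single trifluoromethyl group remains open. Also open, going by these compounds, is how an amine or an ethoxy group at the same place on the ring would read in this assay.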